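Swapping the aryl group on a dihydropyridine calcium channel blocker

This account rests on a few compounds, and the source may have more. Where it says the series, first, only, none or still open, it means among the compounds named here.

Measured so far:
compound 1 `CC1=NC(C)=C(C(=O)O)C(c2ccccc2)/C1=C(\O)OC/C=C/c1ccccc1`: 2000 nM
compound 2 `CC1=NC(C)=C(C(=O)O)C(c2cccc(Cl)c2)/C1=C(\O)OC/C=C/c1ccccc1`: 1000 nM

Both compounds were tested in a functional assay on IMR-32 cells for inhibition of Voltage-dependent N-type calcium channel subunit alpha-1B (Homo sapiens), read by calcium flux; a lower number here means a stronger inhibitor, a higher number a weaker inhibitor. Compound 1 gives 2000 nM and compound 2 gives 1000 nM. For the measured compounds named here, compound 2 therefore shows the lower of the two numbers, but the single step that separates them, a 2.0-fold lower number from compound 1 to compound 2 (0.30 log units; within the scatter), does not rise above the scatter of this assay, so the two compounds cannot be told apart with confidence.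

The next compound, compound 3 `CC1=NC(C)=C(C(=O)O)C(c2ccoc2)/C1=C(\O)OC/C=C/c1ccccc1`, has not been measured. It differs from compound 2 in one place: furan-3-yl in place of 3-chlorophenyl on a saturated ring carbon. Going by the values given here, the only step recorded so far concerns a chloro group added to the phenyl ring, and it was too small to be meaningful. Among the compounds with values here, there is no recorded step in which the phenyl ring itself is exchanged for a smaller heteroaromatic ring, so nothing in the data directly predicts the effect. Without such evidence, the expectation is that compound 3 stays near compound 2, with a modest drift toward a higher number allowed, expressed as a 2.5-fold higher number from compound 2 to compound 3 (0.40 log units; beyond the scatter). Compound 3 is estimated at 2500 nM, within 800 nM to 8000 nM.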

Compound 3, half-maximal inhibitory concentration: 11000 nM
Beside the measured number, compound 3's estimate is 4.4-fold (0.64 log units) below it, outside the stated range (above it).
By their numbers in this assay, from the lowest: compounds 2 and 1 (each within the scatter of the next); then compound 3.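

In this assay exchanging the ring itself on the saturated ring carbon gives an 11-fold higher number from compound 2 to compound 3 (1.04 log units; beyond the scatter) and, starting from the plain phenyl ring, a 5.5-fold higher number from compound 1 to compound 3 (0.74 log units; beyond the scatter) as the same furan-3-yl ring enters. This position looked indifferent when only a chloro group was added to the phenyl ring, yet it clearly responds when that ring gives way to furan-3-yl, and compound 3 is the weakest of the three. The furan-3-yl ring differs from the phenyl rings at once in being five-membered and in holding a ring oxygen, and no measurement at hand separates these two differences or gives a reason for the step.

The compounds shown leave open whether the ring size or the ring oxygen carries the step: a thiophen-3-yl ring would keep the five-membered ring without the oxygen, while a pyridin-3-yl ring would keep the six-membered ring with a hetero atom. They also leave open whether a non-aromatic ring such as cyclohexyl, or a furan-3-yl ring bearing a chloro group, would sit nearer compound 2 or nearer compound 3.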